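A few compounds are considered here, and "the series" means these few. Any claim that something is new, unique, unknown or untested is made for them only; others in the source may bear on it.

Compound 1 `COc1ccc(-c2cc(-c3ccc(Cl)cc3)n(C3C(=O)Nc4ccc(Br)cc43)n2)cc1` gives 67000 nM in a functional assay on cells (Leukemia cell, Homo sapiens) for cytotoxicity, read by sulforhodamine B assay, with a stated time of 48 h; on this read-out higher numbers stand for weaker inhibition of growth and lower numbers for stronger inhibition of growth. Within the data shown here, compound 2 `COc1ccc(-c2cc(-c3ccc(Cl)cc3)n(C3C(=O)Nc4ccc(Cl)cc43)n2)cc1`, at 79200 nM, stands alongside it, the only recorded step being a 1.2-fold higher number from compound 1 to compound 2 (0.07 log units; within the scatter). Compound 3 `O=C1Nc2ccc(Br)cc2C1n1nc(-c2ccc3ccccc3c2)cc1-c1ccc(Cl)cc1` differs from compound 1 by naphthalen-2-yl in place of 4-methoxyphenyl on an aromatic carbon. Among the measured compounds shown here, the one measured step concerns a halogen swap on the shared core and does not involve the aryl group that changes here, so no measured step bears on the move to compound 3. With nothing to lean on, no shift beyond the scatter is assumed. Compound 3 is expected near 67000 nM, with a range from 25000 nM to 150000 nM. This amounts to an expected no change at the digits printed from compound 1 to compound 3 (within the scatter).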

Compound 3, concentration for total growth inhibition: 15200 nM
For compound 3 the middle estimate is 4.4-fold (0.64 log units) above the measured one, outside the stated range (below it).
By their numbers in this assay, from the lowest: compound 3; then compounds 1 and 2 (each within the scatter of the next).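

In this assay, among these compounds, the step of a 4.4-fold lower number from compound 1 to compound 3 (0.64 log units; beyond the scatter) is the first one beyond the scatter, so the aryl group on this aromatic carbon of the five-membered aromatic ring affects the read-out, unlike the halogen swap on the shared core. The change replaces one six-membered aromatic ring with two and removes the hydrogen-bond acceptor, and these two differences cannot be separated here. No evidence on the origin of the step is available.

Open, going by these compounds, is whether an unsubstituted phenyl, a pyridine or a carboxylic acid at this position would follow naphthalen-2-yl. Also open, on these data alone, is whether chloro in place of bromo stays within the scatter with naphthalen-2-yl present.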